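Aryl exchange on compound 3: pyridin-3-yl to 3-methoxyphenyl

The source may hold more compounds than are shown below. What is called first, only, known or untested is meant among the compounds shown, and "the series" means these compounds.

Measured so far in an assay on HEK293 cells for activation of Kir3.1/Kir3.2 (Homo sapiens), read by thallium flux; on this read-out higher numbers stand for an effect only at larger amounts of compound and lower numbers for an effect already at smaller amounts:
- compound 1, `Cc1cc(NC(=O)Cn2nnc(-c3ccccc3)n2)n(C2CCS(=O)(=O)CC2)n1`, gives > 10000 nM, which is a limit of this assay and not a number.
- compound 2, `Cc1cc(NC(=O)Cn2nnc(-c3ccccc3)n2)n(Cc2ccccc2)n1`, gives 495 nM.
- compound 3, `Cc1cc(NC(=O)Cn2nnc(-c3cccnc3)n2)n(C2CCCCC2)n1`, gives 1930 nM.

Of the two numbers in hand, compound 3 stands at the highest, and the gap from compound 3 down to compound 2 lies beyond the scatter. Within the data shown here, the only step measured between compounds that differ in one place is an at least 20-fold lower number from compound 1 to compound 2 (1.30 log units; beyond the scatter), which concerns the group on an aromatic nitrogen of the shared core, and compound 1 sits at the limit of > 10000 nM in this assay, at which 1 of the 3 values shown sits.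

Compound 4, `COc1cccc(-c2nnn(CC(=O)Nc3cc(C)nn3C3CCCCC3)n2)c1`, differs from compound 3 by 3-methoxyphenyl in place of pyridin-3-yl on an aromatic carbon. This change sits on the aromatic carbon of the other ring, not where the measured step lies, so that step gives no direct guide. Among the measured compounds shown here, no other pair in hand varies this group. The expectation therefore rests on compound 3 alone, with wide uncertainty, and the step from compound 3 to compound 4 is estimated as a 1.6-fold lower number from compound 3 to compound 4 (0.21 log units; within the scatter). Compound 4 is expected to give about 1200 nM in this assay, within a range from 350 nM to 4500 nM.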

Compound 4, half-maximal effective concentration: 117 nM
Estimate against measurement, compound 4: 10-fold (1.01 log units) above, outside the stated range (below it).
By their numbers in this assay, from the lowest: compound 4; then compound 2; then compound 3. At a limit, above all of these: compound 1.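

In this assay, among these compounds, the exchange of pyridin-3-yl for 3-methoxyphenyl gives a 16-fold lower number from compound 3 to compound 4 (1.22 log units; beyond the scatter), so the group on this aromatic carbon also moves the read-out, whereas the only earlier step, an at least 20-fold lower number from compound 1 to compound 2 (1.30 log units; beyond the scatter), concerned the group on an aromatic nitrogen. The two groups have the same counts of hydrogen-bond donors and acceptors and carry no net charge, so those counts do not separate them; they differ in the ring nitrogen, present only in pyridin-3-yl, and in the methoxy group, present only in 3-methoxyphenyl. Nothing in the available evidence bears on why this exchange has so large an effect.

The single exchange changes the ring nitrogen and the methoxy group together, and no pair shown tells which of the two carries the step; a plain phenyl on the otherwise unchanged structure of compound 3 would separate them. From the compounds shown here alone, whether the methoxy group can be replaced also stays open, for example by an ethoxy group, a chlorine atom or a dimethylamino group on the same aryl ring.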